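The source may report more compounds than this note shows. Statements on the series, on what has been measured and on what is new or still open speak of the compounds shown alone.

Compound 1 `CCC[S+]([O-])c1sc2ncccc2c1N` — 151 nM
Compound 2 `COCCC[S+]([O-])c1sc2nc(-c3nccs3)cc(-c3cnc(C)n3C)c2c1N` — 3.3 nM
Compound 3 `CCC[S+]([O-])c1sc2nc(-c3cccs3)cc(C(=O)O)c2c1N` — 71 nM

Of the compounds shown here, three sharing a common core have so far been measured in an assay for inhibition of 15-hydroxyprostaglandin dehydrogenase [NAD(+)] (Homo sapiens), read by fluorescence, with a stated time of 15 min, in the presence of a further agent that is not named here; on this read-out higher numbers stand for weaker inhibition and lower numbers for stronger inhibition. Compound 2 stands lowest of the three: its number lies well below that of compound 3, and further still below that of compound 1, and both of these gaps are beyond the usual scatter of this measurement. Compound 4 `CCCCS(=O)(=O)c1sc2nc(-c3nccs3)cc(-c3cnc(C)n3C)c2c1N` has not yet been measured in this assay. It differs from compound 2 in a single place: a group of 7 heavy atoms (4 carbon, 2 oxygen, 1 sulfur; no ring) in place of a group of 7 heavy atoms (4 carbon, 2 oxygen, 1 sulfur; no ring), on an aromatic carbon Butylsulfonyl enters where a group made of the same atoms, joined differently, leaves, on an aromatic carbon of a five-membered aromatic ring with 1 sulfur that is part of a fused system of two rings. Among the compounds with values here, no step between two measured compounds differing in one place is available, so nothing already measured shows how large such a change tends to be. The step of a 2.4-fold higher number from compound 2 to compound 4 (0.38 log units; beyond the scatter) is expected to be modest, toward a somewhat higher number, and it may well fall within the scatter. Compound 4 is accordingly estimated at 8 nM, with a range from 2 nM to 40 nM.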

Compound 4, half-maximal inhibitory concentration: 32 nM
For compound 4 the middle estimate is 4.0-fold (0.60 log units) below the measured one, and the stated range covers the measured number.
By their numbers in this assay, from the lowest: compound 2; then compound 4; then compound 3; then compound 1.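

In this assay, putting butylsulfonyl on this aromatic carbon in place of a group of the same atoms, joined differently, gives a 9.7-fold higher number from compound 2 to compound 4 (0.99 log units; beyond the scatter) at this position. This is the only step shown at a single place, and it shows that the number responds to how these atoms are joined at the position next to the ring sulfur, even though the counts of heavy atoms, hydrogen-bond donors and hydrogen-bond acceptors stay the same. Nothing given here accounts for the size of this step.

The compounds shown leave open how much of the step belongs to the sulfur group and how much to the chain, which a butylsulfinyl or a methoxypropylsulfonyl group would separate. They also leave open whether a shorter chain such as propylsulfonyl, or an amine at the chain end, would bring the number closer to that of compound 2.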